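This account rests on a few compounds, and the source may have more. Where it says the series, first, only, none or still open, it means among the compounds named here.

Measured compounds in a functional assay on A549 cells (Homo sapiens) for cytotoxicity, read by MTT assay, with a stated time of 72 h; on this read-out higher numbers stand for weaker inhibition and lower numbers for stronger inhibition:
- compound 1 `COc1cc(/C=C/C(=O)Nc2cc3c(Nc4ccc(F)c(Cl)c4)ncnc3cc2OC)cc(OC)c1`: "not active" (no number reported)
- compound 2 `COc1cc2ncnc(Nc3ccc(F)c(Cl)c3)c2cc1NC(=O)/C=C/c1cc(OC)c(OC)c(OC)c1`: "not active" (no number reported)
- compound 3 `COc1cc2ncnc(Nc3ccc(F)c(Cl)c3)c2cc1NC(=O)/C=C/c1ccccc1[N+](=O)[O-]`: 33300 nM

Among the measured compounds shown here, compound 3 carries the only number in this assay; for compound 1 and compound 2 no number is reported, only the note that each is not active. Compound 3 thus stands as the one entry with a measurable read-out, and its value is weak.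

Compound 4 `COc1ccc(/C=C/C(=O)Nc2cc3c(Nc4ccc(F)c(Cl)c4)ncnc3cc2OC)cc1` is not yet measured. It differs from compound 3 by 4-methoxyphenyl in place of 2-nitrophenyl on a double-bonded chain carbon bound to a double-bonded chain carbon.

For the measured compounds named here, no step between measured compounds is available to calibrate this change. With compound 1 and compound 2 both recorded as not active, the expectation for compound 4 is a step toward weaker inhibition beyond the scatter, a 2.1-fold higher number from compound 3 to compound 4 (0.32 log units; beyond the scatter), with a real chance of no number at all. Compound 4 is estimated at 70000 nM, range 25000 nM to 200000 nM.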

Compound 4, half-maximal inhibitory concentration: "not active" (no number reported)
The entry for compound 4 holds no number; the estimate stays without a comparison.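

Among the compounds shown here, no new step can be read: compound 4, like compound 1 and compound 2, is recorded as not active in this assay and compound 3 at 33300 nM remains the only number. As far as these compounds go, the size of the change from 2-nitrophenyl to 4-methoxyphenyl stays open. No supporting data bear on this result.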